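A few compounds are considered here, and "the series" means these few. Any claim that something is new, unique, unknown or untested is made for them only; others in the source may bear on it.

Measured so far:
- compound 1, `O=[N+]([O-])c1ccc2c(c1)N(S(=O)(=O)c1ccc(-c3cnc(C4CC4)o3)cc1)CCCO2`: 119 nM
- compound 2, `O=S(=O)(c1ccc(-c2cnc(C3CC3)o2)cc1)N1CCCc2ccccc21`: 38 nM

Both were tested in a functional assay on PC-3 cells (Homo sapiens) for antiproliferative activity, read by MTT assay, with a stated time of 72 h; on this read-out lower numbers stand for stronger inhibition and higher numbers for weaker inhibition. Compound 1 gives the highest of the two numbers; compound 2 sits at a lower number, a gap beyond the usual scatter, so compound 2 is the stronger inhibitor of the pair. Among the measured compounds shown here, no step between these two is set out here, because they differ in more than one place, and only what their two values show can be said.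

Compound 3, `O=S(=O)(c1ccc(-c2cnc(C3CC3)o2)cc1)N1CCCOc2ccc(Cl)cc21`, has not yet been measured. It keeps the core of compound 1 and differs from it in one place: chloro in place of nitro on an aromatic carbon. No change of this kind has been measured in this set, so there is nothing to lean on beyond the value of compound 1 itself. A step at most of a modest size is expected, if anything toward a lower number, and it may well stay within the scatter. For compound 3 the expected value in this assay is 80 nM, with a range from 30 nM to 250 nM, meaning an expected step of a 1.5-fold lower number from compound 1 to compound 3 (0.17 log units; within the scatter).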

Compound 3, half-maximal inhibitory concentration: 18 nM
Compound 3: the middle estimate sits 4.4-fold (0.65 log units) above what was measured; the measured number lies below the stated range.
By their numbers in this assay, from the lowest: compound 3; then compound 2; then compound 1.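

In this assay, putting chloro in place of nitro on this aromatic carbon gives a 6.6-fold lower number from compound 1 to compound 3 (0.82 log units; beyond the scatter), so the group held at this position clearly affects the read-out. Among the compounds shown here, until now the set held no pair differing in one place, and the value of compound 1 alone could not show whether this position mattered at all. No measurement at hand explains why the exchange has this effect.

The compounds shown leave open whether the lower number is particular to chloro or would also come with another group here, such as fluoro, methyl, methoxy or an amine. They also leave open what plain hydrogen on this carbon would give, and so whether chloro lowers the number or nitro raises it.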